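The source may report more compounds than this note shows. Statements on the series, on what has been measured and on what is new or still open speak of the compounds shown alone.

Of the compounds shown here, three built on one shared core have been measured in a functional assay on MGC-803 cells (Homo sapiens) for antiproliferative activity, read by CCK-8 assay, with a stated time of 72 h, tested at 2 uM; on this read-out higher numbers stand for a stronger effect at the one concentration tested and lower numbers for a weaker effect. Compound 1 `COc1ccc(N2CCN(C(=S)SCc3ccc(C(=O)Nc4ccccc4N)cc3)CC2)cc1` gives 25.3% in this assay. Compound 2 `Nc1ccccc1NC(=O)c1ccc(CSC(=S)N2CCN(Cc3ccncc3)CC2)cc1` gives 18.4% in this assay, and compound 3 `Nc1ccccc1NC(=O)c1ccc(CSC(=S)N2CCN(Cc3cccnc3)CC2)cc1` gives 37.7% in this assay, the highest of the three numbers. The step of a number 6.9 percentage points lower from compound 1 to compound 2 (within the scatter) lies within the scatter, whereas a number 12.4 percentage points higher from compound 1 to compound 3 (beyond the scatter) and a number 19.3 percentage points higher from compound 2 to compound 3 (beyond the scatter) are modest rises beyond it.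

Compound 4 `Nc1ccccc1NC(=O)c1ccc(CSC(=S)N2CCN(c3ccncc3)CC2)cc1` has not yet been measured. It differs from compound 3 in one place: pyridin-4-yl in place of (pyridin-3-yl)methyl on an amine nitrogen in a ring. Among the measured compounds shown here, two measured steps bear on this. The step of a number 19.3 percentage points higher from compound 2 to compound 3 (beyond the scatter) shows that exchanging pyridin-4-yl for pyridin-3-yl raised the number, so the reverse exchange is expected to lower it. The step of a number 6.9 percentage points lower from compound 1 to compound 2 (within the scatter) shows that 4-methoxyphenyl sitting directly on the ring nitrogen and (pyridin-4-yl)methyl gave numbers within the scatter of each other. The expected step is therefore a fall, a number 15.7 percentage points lower from compound 3 to compound 4 (beyond the scatter). Compound 4 in this assay is estimated at 22%, within a range from 8% to 38%.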

Compound 4, a percentage reported as inhibition, at one concentration (the size of the read-out at that concentration, not a potency): 64.8%
The estimate for compound 4 lay 42.8 percentage points below the measured number; the measured number lies above the stated range.
By their numbers in this assay, from the lowest: compounds 2 and 1 (each within the scatter of the next); then compound 3; then compound 4.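

In this assay, among the compounds shown here, the group on this ring nitrogen turns out to matter far more than the earlier compounds suggested: removing the methyl link from (pyridin-4-yl)methyl gives a number 46.4 percentage points higher from compound 2 to compound 4 (beyond the scatter) and is the only change between the two. An aromatic ring sitting directly on that nitrogen is not enough on its own, since putting pyridin-4-yl in place of 4-methoxyphenyl gives a number 39.5 percentage points higher from compound 1 to compound 4 (beyond the scatter) with the rest of the molecule unchanged. The step of a number 27.1 percentage points higher from compound 3 to compound 4 (beyond the scatter) adds that pyridin-4-yl on the nitrogen also outdoes (pyridin-3-yl)methyl, although pyridin-3-yl had given the higher number of the two methyl-linked groups.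

Still open, from the compounds shown here alone, is how pyridin-3-yl or pyridin-2-yl bound directly to the ring nitrogen, or a two-carbon chain carrying pyridin-4-yl, would compare. Nothing available explains why these changes have such different effects.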